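The source may report more compounds than this note shows. Statements on the series, on what has been measured and on what is new or still open speak of the compounds shown alone.

Measured in a functional assay on HT-29 cells (Homo sapiens) for inhibition, read by MTT assay, with a stated time of 2 days; on this read-out higher numbers stand for weaker inhibition and lower numbers for stronger inhibition:
- Compound 1 `Nc1cccc(/C=C/c2ccccc2)c1`: 12.9 ug/mL
- Compound 2 `Oc1cccc(/C=C/c2cccc(O)c2)c1`: 25.9 ug/mL
- Compound 3 `Nc1cccc(/C=C/c2cccc(O)c2)c1`: 43 ug/mL

Compound 3 has the highest number of the three only in relation to compound 1, with a 3.3-fold higher number from compound 1 to compound 3 (0.52 log units; beyond the scatter). It cannot be told apart from compound 2, given a 1.7-fold higher number from compound 2 to compound 3 (0.22 log units; within the scatter).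

Compound 4 `COc1cccc(/C=C/c2cccc(O)c2)c1` has not yet been measured. It differs from compound 3 by one change: methoxy in place of amino on an aromatic carbon. This puts methoxy in place of amino on an aromatic carbon, and the hydroxy group stays.

Among the compounds with values here, no measured compound in this set carries methoxy, so the evidence is indirect. The closest guide is the exchange at the same place, where a 1.7-fold higher number from compound 2 to compound 3 (0.22 log units; within the scatter). The other measured step, a 3.3-fold higher number from compound 1 to compound 3 (0.52 log units; beyond the scatter), is modest but concerns the addition of the hydroxy group, which compound 4 retains. On that basis, no step beyond the scatter is expected in this assay.

The expected result is a 1.3-fold lower number from compound 3 to compound 4 (0.13 log units; within the scatter). Compound 4 is estimated at 32 ug/mL, with an expected range from 13 ug/mL to 75 ug/mL.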

Compound 4, half-maximal inhibitory concentration: 11.5 ug/mL
Estimate against measurement, compound 4: 2.8-fold (0.44 log units) above; measured number outside the range, below it.
By their numbers in this assay, from the lowest: compounds 4, 1, 2 and 3 (each within the scatter of the next, the first and the last beyond it).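

In this assay, putting methoxy in place of amino on an aromatic carbon gives a 3.7-fold lower number from compound 3 to compound 4 (0.57 log units; beyond the scatter), so this position does respond to the group it carries, although the earlier exchange of hydroxy for amino there gave only a 1.7-fold higher number from compound 2 to compound 3 (0.22 log units; within the scatter). Placing methyl on the oxygen of the hydroxy group at this position gives a 2.3-fold lower number from compound 2 to compound 4 (0.35 log units; beyond the scatter), which separates methoxy from hydroxy as well as from amino, while the hydroxy group at the other end of the molecule stays in place throughout. No measurement in this set accounts for the gain seen with methoxy.

The compounds shown leave open whether an ethoxy group or a longer alkoxy chain at this position would keep the lower number. They also leave open how a fluorine atom or a carboxylic acid would behave there.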